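Swapping 2,2-dimethylbutyl for sec-butyl on compound 3

This account rests on a few compounds, and the source may have more. Where it says the series, first, only, none or still open, it means among the compounds named here.

- compound 1 `CC(C)CCn1nc(-c2cccs2)c(O)c(C2=NS(=O)(=O)c3cc(S(N)(=O)=O)ccc3N2)c1=O` gives > 33000 nM
- compound 2 `CC(C)CCc1nn(CCC(C)C)c(=O)c(C2=NS(=O)(=O)c3cc(NS(C)(=O)=O)ccc3N2)c1O` gives > 33000 nM
- compound 3 `CCC(C)(C)Cn1nc(-c2cccs2)c(O)c(C2=NS(=O)(=O)c3cc(NS(C)(=O)=O)ccc3N2)c1=O` gives > 1000 nM

In an ADME assay on Huh-7 cells (Homo sapiens) for cytotoxicity, with a stated time of 72 h (on this read-out higher numbers stand for lower toxicity in this test and lower numbers for higher toxicity in this test), compound 3 gives > 1000 nM, and this is a limit, not a number. Compound 1 gives > 33000 nM, which is also a limit. Compound 2 gives > 33000 nM, again a limit. For the measured compounds named here, none of the three compounds has yet returned a number, so no measured step is available to guide the next one.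

Compound 4 `CCC(C)n1nc(-c2cccs2)c(O)c(C2=NS(=O)(=O)c3cc(NS(C)(=O)=O)ccc3N2)c1=O` differs from compound 3 at one place. It has sec-butyl in place of 2,2-dimethylbutyl on an aromatic nitrogen, and it keeps the thiophen-2-yl group.

The expectation rests on compound 1, which also carries the thiophen-2-yl group and gives > 33000 nM as a limit. In this assay the expected change is upward from the limit of compound 3, towards lower toxicity in this test. The estimated step is a step that the limit leaves unreadable from compound 3 to compound 4, and it is only as firm as a comparison with a limit allows. A limit rather than a number is the most likely report. For compound 4 the estimate is 33000 nM, with an expected range from 8000 nM to 70000 nM.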

Compound 4, half-maximal cytotoxic concentration: > 33000 nM
Compound 4 gave a limit, no number (the forecaster's own chance of this, stated with the estimate: 85%); the middle value sits exactly at the limit.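

In this assay compound 3 gives > 1000 nM, which is a limit. Compound 4 gives > 33000 nM, also a limit. For the compounds shown here, no step between compound 3 and compound 4 can be read from these two limits. The compounds shown leave open whether sec-butyl and 2,2-dimethylbutyl differ at all in this assay.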